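Swapping an amide for a piperidine on the side chain

This account rests on a few compounds, and the source may have more. Where it says the series, first, only, none or still open, it means among the compounds named here.

Measured compounds:
- compound 1, `C=CC[C@@H]1C[C@@H](c2ccc(Cl)c(Cl)c2)[C@H](NC(=O)c2cc(-c3c(Cl)cnn3C)c(Cl)o2)CN1`: 990 nM
- compound 2, `Cn1ncc(Cl)c1-c1cc(C(=O)N[C@@H]2CN[C@H](CC(=O)NC3CCC3)C[C@H]2c2ccc(Cl)c(Cl)c2)oc1Cl`: 610 nM
- compound 3, `CNC(=O)C[C@@H]1C[C@@H](c2ccc(Cl)c(Cl)c2)[C@H](NC(=O)c2cc(-c3c(Cl)cnn3C)c(Cl)o2)CN1`: 1130 nM

These three compounds share one core and differ only in the group hanging from a saturated chain carbon bound to a saturated ring carbon. In a functional assay on OVCAR-8 cells (Homo sapiens) for antiproliferative activity (on this read-out lower numbers stand for stronger inhibition and higher numbers for weaker inhibition), compound 3 gives the highest of the three numbers, but its steps to the others, a 1.1-fold higher number from compound 1 to compound 3 (0.06 log units; within the scatter) and a 1.9-fold higher number from compound 2 to compound 3 (0.27 log units; within the scatter), are both within the scatter, so no ordering among the three can be claimed.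

Compound 4, `Cn1ncc(Cl)c1-c1cc(C(=O)N[C@@H]2CN[C@H](CCN3CCCCC3)C[C@H]2c2ccc(Cl)c(Cl)c2)oc1Cl`, has not yet been measured. It differs from compound 3 by (piperidin-1-yl)methyl in place of methylcarbamoyl on a saturated chain carbon bound to a saturated ring carbon. The three measured steps all touch the same place: a 1.6-fold lower number from compound 1 to compound 2 (0.21 log units; within the scatter) and the two already named. Going by the values given here, none of them brings in a ring amine in place of an amide, so no step bears directly on this change; what they show is that varying this group has so far moved this assay only within the scatter.

On that basis compound 4 is expected to give 900 nM in this assay, with a range from 300 nM to 2700 nM, which means an estimated step of a 1.3-fold lower number from compound 3 to compound 4 (0.10 log units; within the scatter), not beyond the scatter.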

Compound 4, half-maximal inhibitory concentration: 1660 nM
For compound 4 the middle estimate is 1.8-fold (0.27 log units) below the measured one, within the range that was stated.
By their numbers in this assay, from the lowest: compounds 2, 1, 3 and 4 (each within the scatter of the next, the first and the last beyond it).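

Going by these compounds alone, putting a ring amine on this side chain gives the first step at this position that lies beyond the scatter in this assay, and it is a modest one: a 2.7-fold higher number from compound 2 to compound 4 (0.43 log units; beyond the scatter), with (piperidin-1-yl)methyl in place of cyclobutylcarbamoyl. Against the other two groups the same change does not separate the compounds, with a 1.5-fold higher number from compound 3 to compound 4 (0.17 log units; within the scatter) against methylcarbamoyl and a 1.7-fold higher number from compound 1 to compound 4 (0.22 log units; within the scatter) against vinyl, so only compound 2 and compound 4 can be told apart, and the position still shows no wide spread across these four very different groups. Nothing available here accounts for why the step from the cyclobutyl amide alone clears the scatter.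

The compounds shown leave open whether the piperidine ring as a whole or its nitrogen matters for this step, and a morpholine or an open-chain dimethylamino group on the same chain would speak to that. They also leave open whether a carboxylic acid or a longer chain at this place would move the number further than any group seen so far.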